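The compounds below may be only part of what the source reports. "The series", "measured", "known", "first", "only" and "open" are said of these compounds alone.

Compound 1 `O=C(CCc1cccc2c1B(O)OC2)Nc1ccc(Cl)cc1` gives 12000 nM in a functional assay on HCT-116 cells (Homo sapiens) for antiproliferative activity, read by MTT assay, with a stated time of 72 h; a higher number here means a weaker inhibitor, a lower number a stronger inhibitor.
Compound 2 `O=C(CCc1cccc2c1B(O)OC2)Nc1ccc([N+](=O)[O-])cc1` gives only the limit > 100000 nM in this assay.
Compound 3 `C#Cc1cccc(NC(=O)CCc2cccc3c2B(O)OC3)c1` gives 3600 nM in this assay.

All three compounds share one core and differ only in the group on the aniline ring of the amide. Compound 3 has the lowest number among the values shown; the nearest number belongs to compound 1, which sits higher than compound 3 by a gap beyond the scatter. Compound 2 gives no number at all, only a limit, described by the limit of > 100000 nM in this assay, at which 1 of the 3 values shown sits. Within the data shown here, the one measured step, an at least 8.3-fold higher number from compound 1 to compound 2 (0.92 log units; beyond the scatter), exchanges a chloro for a nitro and moves the number sharply upward.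

Compound 4 `CSc1cccc(-c2cccc(NC(=O)CCc3cccc4c3B(O)OC4)c2)c1` is not yet measured. It differs from compound 3 by 3-(methylsulfanyl)phenyl in place of ethynyl on an aromatic carbon. Among the measured compounds shown here, no measured step exchanges an ethynyl for a larger aromatic group, so the step from compound 1 to compound 2 does not bear on this change, and no direction can be drawn from the data. The expectation for compound 4 therefore rests on compound 3 alone, with wide uncertainty: the number is expected to stay near that of compound 3, a step of a 1.2-fold lower number from compound 3 to compound 4 (0.08 log units; within the scatter). Compound 4 is thus estimated at 3000 nM, with a range from 700 nM to 13000 nM.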

Compound 4, half-maximal inhibitory concentration: 110 nM
The estimate for compound 4 lay 27-fold (1.44 log units) above the measured number; the measured number lies below the stated range.
By their numbers in this assay, from the lowest: compound 4; then compound 3; then compound 1. At a limit, above all of these: compound 2.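

Among these compounds, the exchange of ethynyl for 3-(methylsulfanyl)phenyl gives a 33-fold lower number from compound 3 to compound 4 (1.51 log units; beyond the scatter) in this assay, the only measured step here that lowers the number. None of the earlier groups on the aniline ring carried a ring of its own, so compound 4 adds something new: this position accepts a group of 8 heavy atoms that includes a six-membered aromatic ring, and in its presence the number falls well beyond the scatter. Nothing measured here explains why this exchange lowers the number so strongly.

The compounds shown do not separate the contribution of the added aromatic ring from that of the methylsulfanyl group on it, a question that a plain phenyl, or an added ring carrying an amine or a carboxylic acid in place of the methylsulfanyl group, would address. They also leave open whether the rest of the molecule can change while this low number is kept, for instance with a longer chain joining the shared core to the amide.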